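Trimming Ethoxy to Methyl: What the Data Suggest

The source may report more compounds than this note shows. Statements on the series, on what has been measured and on what is new or still open speak of the compounds shown alone.

Measured compounds:
- compound 1 `COC(=O)/C=C/c1cccc(N(Cc2ccc(/C=C/c3c(F)cccc3F)cc2)C(=O)C(C)C)c1`: 108 nM
- compound 2 `COC(=O)/C=C/c1cccc(N(Cc2ccc(/C=C/c3c(C)cc(C)cc3C)cc2)C(=O)C(C)C)c1`: 149 nM
- compound 3 `CCOc1cccc(-c2ccc(CN(C(=O)C(C)C)c3cccc(/C=C/C(=O)OC)c3)cc2)c1`: 173 nM

In an assay on isolated protein with Bile acid receptor (Homo sapiens) as the target (on this read-out lower numbers stand for an effect already at smaller amounts and higher numbers for an effect only at larger amounts of compound), compound 3 gives the highest of the three numbers, but its gaps to the others are small: a 1.6-fold higher number from compound 1 to compound 3 (0.20 log units; within the scatter) and a 1.2-fold higher number from compound 2 to compound 3 (0.06 log units; within the scatter) both lie within the scatter, so the three compounds cannot be told apart on this read-out.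

Compound 4 `COC(=O)/C=C/c1cccc(N(Cc2ccc(-c3cccc(C)c3)cc2)C(=O)C(C)C)c1` has not yet been measured. It differs from compound 3 in one place: methyl in place of ethoxy on an aromatic carbon. For the measured compounds named here, none of the measured steps makes exactly this change, so there is no direct precedent. What the measured steps do show is that the whole terminal group can be exchanged, as in a 1.6-fold higher number from compound 1 to compound 3 (0.20 log units; within the scatter) and a 1.2-fold higher number from compound 2 to compound 3 (0.06 log units; within the scatter), without moving the number beyond the scatter. A change confined to a single substituent on that terminal ring is smaller than those exchanges.

On that basis no step beyond the scatter is expected in this assay, in either direction. For compound 4 the expected step is a 1.2-fold higher number from compound 3 to compound 4 (0.06 log units; within the scatter), giving an estimated value of 200 nM, with a likely range from 90 nM to 450 nM.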

Compound 4, half-maximal effective concentration: 163 nM
Estimate against measurement, compound 4: 1.2-fold (0.09 log units) above, within the range that was stated.
By their numbers in this assay, from the lowest: compounds 1, 2, 4 and 3 (each within the scatter of the next).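

In this assay the change from ethoxy to methyl, on an aromatic carbon meta to a large group, stays within the scatter (a 1.1-fold lower number from compound 3 to compound 4 (0.03 log units; within the scatter)), even though three heavy atoms including a hydrogen-bond acceptor give way to a single carbon. For the compounds shown here, this is the first look at a single substituent on this terminal ring, and it shows that, between these two compounds, neither the oxygen nor the extra carbon is needed to keep the number where it is. The 3-methylphenyl group also cannot be told apart from the two larger ethenyl-linked groups (a 1.1-fold higher number from compound 2 to compound 4 (0.04 log units; within the scatter); a 1.5-fold higher number from compound 1 to compound 4 (0.18 log units; within the scatter)), and no separate measurement is available to explain why this position tolerates these exchanges.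

From the compounds shown here alone, because all four numbers lie so close together, it remains open whether any group at this position can move the number beyond the scatter, for example an amine, a carboxylic acid or a longer chain such as butoxy. Going by these compounds, it is equally open whether the ring would behave the same with only hydrogen in this place.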